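This account rests on a few compounds, and the source may have more. Where it says the series, first, only, none or still open, it means among the compounds named here.

Working notes on the series. Among the measured compounds shown here, in a functional assay on L1210 cells (Mus musculus) for cytotoxicity (on this read-out lower numbers stand for stronger inhibition and higher numbers for weaker inhibition), compound 1 `CC(=O)c1ccc(NC(=O)/C=C/C(=O)N2C/C(=C\c3ccc([N+](=O)[O-])cc3)C(=O)/C(=C/c3ccc([N+](=O)[O-])cc3)C2)cc1` gives 1400 nM, the lowest number of the three measured so far. Compound 2 `CC(=O)c1ccc(NC(=O)/C=C/C(=O)N2C/C(=C\c3ccccc3)C(=O)/C(=C/c3ccccc3)C2)cc1`, which carries no nitro groups, gives 5500 nM in this assay, and compound 3 `Cc1ccc(NC(=O)/C=C/C(=O)N2C/C(=C\c3ccccc3)C(=O)/C(=C/c3ccccc3)C2)cc1C`, bearing a 3,4-dimethylphenyl amide, gives 31000 nM. For the measured compounds named here, the one single-point step measured in this assay is a 5.6-fold higher number from compound 2 to compound 3 (0.75 log units; beyond the scatter), a modest loss beyond the scatter when the acetyl-bearing aryl amide is exchanged.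

Compound 4 `O=C(/C=C/C(=O)N1C/C(=C\c2ccc([N+](=O)[O-])cc2)C(=O)/C(=C/c2ccc([N+](=O)[O-])cc2)C1)Nc1ccccc1` is not yet measured. It differs from compound 1 by hydrogen in place of acetyl on an aromatic carbon, within the same amide aryl group that the step from compound 2 to compound 3 exchanged. That step removed the acetyl but also introduced two methyls, so it bears on the present change only in part: it suggests that losing the acetyl costs something, yet how much of the loss belongs to the acetyl alone cannot be separated from these data. Going by the values given here, the expectation for compound 4 in this assay is therefore a weaker number, with a step smaller than the one from compound 2 to compound 3 but probably beyond the scatter. The estimate for compound 4 is 4200 nM, with a range of 1500 nM to 12000 nM, which means an expected step of a 3.0-fold higher number from compound 1 to compound 4 (0.48 log units; beyond the scatter).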

Compound 4, half-maximal inhibitory concentration: 1800 nM
Compound 4: the middle estimate sits 2.3-fold (0.37 log units) above what was measured; measured number inside the range.
By their numbers in this assay, from the lowest: compounds 1 and 4 (each within the scatter of the next); then compound 2; then compound 3.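

Hydrogen in place of acetyl on an aromatic carbon gives a 1.3-fold higher number from compound 1 to compound 4 (0.11 log units; within the scatter) in this assay, so with the nitro groups of compound 1 in place, 4-acetylphenyl can give way to phenyl without a change beyond the scatter. The earlier step of a 5.6-fold higher number from compound 2 to compound 3 (0.75 log units; beyond the scatter) therefore cannot be read as the price of losing the acetyl alone, since it also brought in two methyl groups and belongs to a core without nitro groups. No measurement at hand bears on the reason for this outcome.

Still open, on these data alone, is whether the acetyl can also be lost without a change beyond the scatter on the core of compound 2, a comparison that would separate the acetyl from the two methyl groups and show whether the nitro groups alter the outcome. Among the compounds shown here, also open is how an amine, a carboxylic acid or a longer chain would read on the same aromatic carbon, para to a large group, since hydrogen and acetyl are the only two groups compared there.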